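Compound 3 to compound 4: 3-methoxyphenyl at the limit

The compounds below may be only part of what the source reports. "The series", "measured", "known", "first", "only" and "open" are said of these compounds alone.

Compound 3 `COc1ccc2c(c1)c(C1CC(c3cc(OC)c(OC)c(OC)c3)=NN1C(=O)c1ccc(OC)nc1)cn2C` gives only a limit in an ADME assay on HEK-293T cells (Homo sapiens) for cytotoxicity, read by MTT assay, with a stated time of 48 h (a higher number here means that more compound is tolerated, a lower number that less compound is tolerated), not a number: > 300000 nM. Compound 1 `COc1ccc2c(c1)c(C1CC(c3ccccc3)=NN1C(=O)c1ccc(OC)nc1)cn2C` also gives only a limit, > 300000 nM. Compound 2 `COc1ccc(C2=NN(C(=O)c3ccc(OC)nc3)C(c3cn(C)c4ccc(OC)cc34)C2)cc1` likewise gives only a limit, > 300000 nM.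

Compound 4 `COc1cccc(C2=NN(C(=O)c3ccc(OC)nc3)C(c3cn(C)c4ccc(OC)cc34)C2)c1` carries 3-methoxyphenyl in place of 3,4,5-trimethoxyphenyl on a carbon with a double bond to nitrogen, with the rest of the core of compound 3 unchanged: 3-methoxyphenyl in place of 3,4,5-trimethoxyphenyl on a carbon with a double bond to nitrogen.

Three measured steps change the group on that same carbon: a step that the two limits leave unreadable from compound 1 to compound 2, a step that the two limits leave unreadable from compound 1 to compound 3 and a step that the two limits leave unreadable from compound 2 to compound 3. None of them has a readable size, so none gives a direction for the new change. Within the data shown here, compound 1, compound 2 and compound 3 all share one limit, (the limit of > 300000 nM in this assay, at which 3 of the 3 values shown sit), and no measured compound in this set goes against it.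

The expected step is a number no higher from compound 3 to compound 4 (the limit leaves the size open), with no change beyond the scatter anticipated in this assay. For compound 4 the estimate is 300000 nM, with an expected range of 120000 nM to 600000 nM, and the reading is expected most likely to come back as a limit again.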

Compound 4, half-maximal cytotoxic concentration: > 300000 nM
Compound 4: no number, only a limit (the forecaster's own chance of this, stated with the estimate: 88%); the middle value sits exactly at the limit.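

In this assay compound 4 gives only a limit, as do compound 1, compound 2 and compound 3, so no step among these four compounds can be read: the limit of > 300000 nM in this assay, at which 4 of the 4 values shown sit.

The compounds shown leave open whether any group on the carbon with a double bond to nitrogen changes the tolerated concentration, and by how much.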